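The compounds below may be only part of what the source reports. "The series", "measured", "known", "first", "only" and "open" are said of these compounds alone.

Working notes on a small series built on one shared core. Compound 3 `Cc1c(/N=C/c2ccccc2)c(=O)n(-c2ccccc2)n1C` is the parent; compound 1 `Cc1c(/N=C/c2cccc(O)c2)c(=O)n(-c2ccccc2)n1C` and compound 2 `COc1cccc(/C=N/c2c(C)n(C)n(-c3ccccc3)c2=O)c1` each carry one added group on the outer ring. In a functional assay on HCT-116 cells (Homo sapiens) for cytotoxicity, read by MTT assay, with a stated time of 72 h (a higher number here means a weaker inhibitor, a lower number a stronger inhibitor), compound 3 gives 589000000 nM, compound 1 gives 617000000 nM and compound 2 gives 933000000 nM. Compound 1 differs from compound 3 by hydroxy in place of hydrogen on an aromatic carbon, with the step of a 1.0-fold higher number from compound 3 to compound 1 (0.02 log units; within the scatter). Compound 2 differs from compound 3 by methoxy in place of hydrogen on an aromatic carbon, and the step reads a 1.6-fold lower number from compound 2 to compound 3 (0.20 log units; within the scatter). Between compound 1 and compound 2 the step is a 1.5-fold higher number from compound 1 to compound 2 (0.18 log units; within the scatter). All three values lie within the scatter of one another, so no ordering is claimed.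

Compound 4 `COc1cccc(/C=N/c2c(C)n(C)n(-c3ccccc3)c2=O)c1O` is not yet measured. It differs from compound 2 by hydroxy in place of hydrogen on an aromatic carbon. For the measured compounds named here, this is the same kind of change as the one from compound 3 to compound 1, not the same: there the place was meta to a large group, here it is ortho to a large group and ortho to a methoxy group. Because the earlier hydroxy step a 1.0-fold higher number from compound 3 to compound 1 (0.02 log units; within the scatter) stayed within the scatter, a step of similar size is expected, a 1.0-fold lower number from compound 2 to compound 4 (0.02 log units; within the scatter). Compound 4 is estimated at 900000000 nM, expected between 400000000 nM and 2000000000 nM.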

Compound 4, half-maximal inhibitory concentration: 89100000 nM
Compound 4: the middle estimate sits 10-fold (1.00 log units) above what was measured; the measured number lies below the stated range.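

In this assay the new step reads a 10-fold lower number from compound 2 to compound 4 (1.02 log units; beyond the scatter), so adding a hydroxy on the core of compound 2 is a large change. The same kind of change does not carry over at the same size from one core to the other: the same change on two cores in this assay, a 1.0-fold higher number (0.02 log units; within the scatter) from compound 3 to compound 1 and a 10-fold lower number (1.02 log units; beyond the scatter) from compound 2 to compound 4, 11-fold (1.04 log units) apart, beyond the scatter of two such steps. For the compounds shown here, this shows only that the earlier hydroxy step cannot be transferred to this series as a constant; it does not show what sets the two steps apart, as the methoxy group and the place of the hydroxy, ortho to a large group and ortho to a methoxy group, change together across this single pair of steps.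

Open, as far as these compounds go, is whether a hydroxy ortho to a large group gives a step of this size on a ring carrying no methoxy group. Also open, from the compounds shown here alone, is whether an amine or a carboxylic acid in place of this hydroxy would go with a similar number.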